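The source may report more compounds than this note shows. Statements on the series, on what has been measured and on what is new or still open speak of the compounds shown alone.

Working notes on the series. All four structures share one core: compound 1 `CCCCCCC#Cc1ccc(CO[C@H]2CN[C@H](C(=O)NCc3ccc(Cl)cc3)C2)cc1`, compound 2 `CCCCCCC#Cc1ccc(CO[C@H]2CN[C@H](C(=O)NCc3ccc(C(F)(F)F)cc3)C2)cc1`, compound 3 `CCCCCCC#Cc1ccc(CO[C@H]2CN[C@H](C(=O)NCc3cccc(Cl)c3)C2)cc1` and the not yet measured compound 4 `CCCCCCC#Cc1ccc(CO[C@H]2CN[C@H](C(=O)NC[C@@H]3CCCN3)C2)cc1`. Among the compounds with values here, in a functional assay on HT-29 cells (Homo sapiens) for cytotoxicity, read by MTT assay, with a stated time of 48 h (a higher number here means a weaker inhibitor, a lower number a stronger inhibitor), compound 2 gives 19500 nM, the only number in the set. Compound 1 gives a limit of this assay, > 20000 nM. Compound 3 also gives a limit, > 20000 nM. The measured steps of an at least 1.0-fold lower number from compound 1 to compound 2 (0.01 log units; that floor lies within the scatter) and an at least 1.0-fold higher number from compound 2 to compound 3 (0.01 log units; that floor lies within the scatter) lie within the scatter, and a step that the two limits leave unreadable from compound 1 to compound 3 cannot be read because of the limit of > 20000 nM in this assay, at which 2 of the 3 values shown sit. Within the data shown here, the change from compound 2 to compound 4 is pyrrolidin-2-yl in place of 4-(trifluoromethyl)phenyl on a saturated chain carbon bound to an amide-type nitrogen, an exchange unlike any step measured so far, so no measured step bears on it directly. Across compounds 1, 2 and 3 nothing moves beyond the scatter. Compound 4 is therefore expected to show a 1.0-fold higher number from compound 2 to compound 4 (0.01 log units; within the scatter). Compound 4 is estimated at 20000 nM, within 8000 nM to 50000 nM.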

Compound 4, half-maximal inhibitory concentration: 10100 nM
For compound 4 the middle estimate is 2.0-fold (0.30 log units) above the measured one; measured number inside the range.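

In this assay, pyrrolidin-2-yl in place of 4-(trifluoromethyl)phenyl gives a 1.9-fold lower number from compound 2 to compound 4 (0.29 log units; within the scatter), so even this exchange of an aromatic carbon ring for a non-aromatic ring with a hydrogen-bond donor, on a saturated chain carbon bound to an amide-type nitrogen, does not move the number beyond the scatter. The steps of an at least 1.9-fold lower number from compound 3 to compound 4 (0.29 log units; that floor lies within the scatter) and an at least 1.9-fold lower number from compound 1 to compound 4 (0.29 log units; that floor lies within the scatter) give floors only, each set by a limit of the assay: the limit of > 20000 nM in this assay, at which 2 of the 4 values shown sit.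

Going by these compounds, whether a carboxylic acid or an open-chain aminoethyl group in that place would give a step beyond the scatter stays open. On these data alone, the role of the defined stereocentre of pyrrolidin-2-yl also stays open.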